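Compound 1 to compound 4: ring nitrogen substituent change

The source may report more compounds than this note shows. Statements on the series, on what has been measured and on what is new or still open speak of the compounds shown alone.

Among the compounds with values here, in a functional assay on NCI-H1975 cells (Homo sapiens) for cytotoxicity, read by MTT assay, with a stated time of 72 h (on this read-out higher numbers stand for weaker inhibition and lower numbers for stronger inhibition), compound 1 `COc1cc(/C=C2\CN(C)C/C(=C\c3cc(OC)c(OC)c(OC)c3)C2=O)cc(OC)c1OC` gives 1000 nM, the lowest of the three numbers measured so far. Compound 2 `CCCN1C/C(=C\c2ccc(OC)c(OC)c2)C(=O)/C(=C/c2ccc(OC)c(OC)c2)C1` gives 11200 nM and compound 3 `CCN1C/C(=C\c2ccc(OC)c(OC)c2)C(=O)/C(=C/c2ccc(OC)c(OC)c2)C1` gives 8500 nM. Compound 4 `COc1cc(/C=C2\CN(C(=O)c3ccccc3F)C/C(=C\c3cc(OC)c(OC)c(OC)c3)C2=O)cc(OC)c1OC` keeps the core of compound 1 and carries (2-fluorophenyl)carbonyl in place of methyl on an amine nitrogen in a ring.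

Within the data shown here, only one measured step bears on this site: a 1.3-fold lower number from compound 2 to compound 3 (0.12 log units; within the scatter). That change is hydrogen in place of methyl on a saturated chain carbon, two bonds along the chain from the amine nitrogen in a ring, and it stays within the scatter. Among the measured compounds shown here, it says little about the much larger group entering here, and no measured compound carries that group. No shift beyond the scatter is therefore expected, in either direction, and the range is kept wide. The expected step is a 1.4-fold lower number from compound 1 to compound 4 (0.15 log units; within the scatter). For compound 4 the estimated value is 700 nM, with an expected range from 170 nM to 3000 nM.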

Compound 4, half-maximal inhibitory concentration: 1400 nM
Estimate against measurement, compound 4: 2.0-fold (0.30 log units) below, and the stated range covers the measured number.
By their numbers in this assay, from the lowest: compounds 1 and 4 (each within the scatter of the next); then compounds 3 and 2 (each within the scatter of the next).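

In this assay the exchange of methyl for (2-fluorophenyl)carbonyl on the amine nitrogen in a ring gives a 1.4-fold higher number from compound 1 to compound 4 (0.15 log units; within the scatter), so on the core of compound 1 this position accepts a much larger group, with a six-membered aromatic ring and a carbonyl, without a shift beyond the scatter. Within the data shown here, the only earlier step near this site, a 1.3-fold lower number from compound 2 to compound 3 (0.12 log units; within the scatter), covered a small change in a saturated chain and could not show this. No measured evidence accounts for the outcome.

The compounds shown leave open whether the fluorine has any part in this result, which a plain benzoyl group on the same nitrogen would test. Also open, on these data alone, is how a benzyl group, without the carbonyl, would compare at this position on the same core.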